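This account rests on a few compounds, and the source may have more. Where it says the series, first, only, none or still open, it means among the compounds named here.

Compound 1 `OC[C@H]1C[C@@H](Cn2cnc3c(-c4ccccc4)ncnc32)c2ccccc21` and compound 2 `Cc1ccc(-c2ncnc3c2ncn3C[C@@H]2C[C@H](CO)c3ccccc32)cc1` share one core, while compound 3 `COc1c(C)c(C)c(OC)c(-c2cn([C@H]3C[C@H](O)[C@@H](CO)O3)c(=O)[nH]c2=O)c1C` and compound 4 `COc1cc(-c2cn([C@H]3C[C@H](O)[C@@H](CO)O3)c(=O)[nH]c2=O)c(OC)c(C)c1C` share another; the difference between the two cores is not broken down here. In an ADME assay on L1210/0 cells (Mus musculus) for cytotoxicity, with a stated time of 48 h (on this read-out higher numbers stand for weaker inhibition and lower numbers for stronger inhibition), compound 2 gives 15400 nM, and compound 1 gives 28100 nM. The change between them, (hydrogen in place of methyl on an aromatic carbon), makes the step of a 1.8-fold higher number from compound 2 to compound 1 (0.26 log units; within the scatter). For compound 3 this assay reports only a limit, > 200000 nM. Compound 4 arises from compound 3 by the same kind of change, (hydrogen in place of methyl on an aromatic carbon), but its surroundings differ: the place is ortho to a large group, ortho to a methoxy group, meta to a methoxy group, meta to a methyl group and para to a methyl group, where the earlier place was para to a large group. Because a 1.8-fold higher number from compound 2 to compound 1 (0.26 log units; within the scatter) lies within the scatter, and because compound 3 sits at the limit of > 200000 nM in this assay, at which 1 of the 3 values shown sits, compound 4 is expected to move by about a step that the limit leaves unreadable from compound 3 to compound 4 in this assay and to give an estimated 300000 nM, between 100000 nM and 1000000 nM, most likely reported again as a limit rather than a number.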

Compound 4, half-maximal inhibitory concentration: > 200000 nM
Compound 4 ended at the assay's limit (the forecaster's own chance of this, stated with the estimate: 80%); the middle value lies beyond the limit too.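

Among these compounds, compound 3 and compound 4 both stand at a limit rather than a number, so no step between them can be read: the limit of > 200000 nM in this assay, at which 2 of the 4 values shown sit.

The compounds shown leave open whether hydrogen in place of methyl on an aromatic carbon shifts the read-out at all on the core of compound 3.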